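Sulfonylquinoline series: aryl sulfone variation at the core

The source may report more compounds than this note shows. Statements on the series, on what has been measured and on what is new or still open speak of the compounds shown alone.

Measured compounds in an assay on isolated protein for displacement of a labelled ligand from metabotropic glutamate receptor 5 (Homo sapiens), with a stated time of 60 min, tested at 1 uM; a higher number here means more inhibition at the concentration tested (going by the name of the read-out), a lower number less inhibition:
- compound 1, `COc1cccc(S(=O)(=O)c2cnc3ccc(Cl)cc3c2N2CCC(C)CC2)c1`, gives 87%
- compound 2, `COc1cccc(S(=O)(=O)c2cnc3ccc(F)cc3c2N2CCC(C)CC2)c1`, gives 90%
- compound 3, `COc1cccc(S(=O)(=O)c2cnc3ccc(C)cc3c2N2CCC(C)CC2)c1`, gives 96%

Compound 1 gives the lowest of the three numbers. The steps of a number 3 percentage points higher from compound 1 to compound 2 (within the scatter) and a number 9 percentage points higher from compound 1 to compound 3 (within the scatter) are both within the scatter, as is a number 6 percentage points higher from compound 2 to compound 3 (within the scatter), so the three compounds cannot be ordered on these numbers.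

Compound 4, `CC1CCN(c2c(S(=O)(=O)c3cc(F)cc(F)c3)cnc3ccc(Cl)cc23)CC1`, has not been measured. It differs from compound 1 in this way: 3,5-difluorophenyl in place of 3-methoxyphenyl on a sulfonyl sulfur. For the measured compounds named here, none of the measured steps bears on this change; all three vary only a substituent on an aromatic carbon of the shared core, while the aryl group on the sulfonyl sulfur stays the same. The expectation for compound 4 therefore rests on the level of compound 1 alone, with a wide range. In this assay compound 4 is expected to give about 80%, between 50% and 97%. Going by the values given here, the step this estimate implies, a number 7 percentage points lower from compound 1 to compound 4 (within the scatter), is expected to be within the scatter, though the data give no step on which to lean.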

Compound 4, a percentage reported as inhibition, at one concentration (the size of the read-out at that concentration, not a potency): 93%
Compound 4: middle estimate off by 13 percentage points, on the low side, within the range that was stated.
By their numbers in this assay, from the lowest: compounds 1, 2, 4 and 3 (each within the scatter of the next).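

The earlier compounds shown here varied only a substituent on an aromatic carbon of the shared core, whereas this pair varies the aryl group on the sulfonyl sulfur. In this assay the exchange of 3-methoxyphenyl for 3,5-difluorophenyl gives a number 6 percentage points higher from compound 1 to compound 4 (within the scatter) and so cannot be told from no change. On the chloro compounds, then, the methoxy group is not needed for a high reading at this concentration, though no measurement on hand accounts for this result.

On these data alone, whether a methyl or a benzyl group on the sulfonyl sulfur would hold the reading stays open, as does whether 3,5-difluorophenyl gives the same picture with the fluoro or methyl substituent on the core. With readings at one concentration only, any difference in potency among these compounds also stays open.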